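The source may hold more compounds than are shown below. What is called first, only, known or untested is meant among the compounds shown, and "the series" means these compounds.

Measured compounds in a functional assay on B16-F10 cells (Mus musculus) for inhibition, read by MTT assay, with a stated time of 72 h; on this read-out lower numbers stand for stronger inhibition and higher numbers for weaker inhibition:
- Compound 1, `N#Cc1c(Nc2cccc(Cl)c2)nc(SCc2cn(Cc3ccccc3Cl)nn2)nc1-c1ccccc1`: 3590 nM
- Compound 2, `N#Cc1c(Nc2cccc([N+](=O)[O-])c2)nc(SCc2cn(Cc3ccccc3Cl)nn2)nc1-c1ccccc1`: 17200 nM
- Compound 3, `N#Cc1c(Nc2ccc(F)cc2)nc(SCc2cn(Cc3ccccc3Cl)nn2)nc1-c1ccccc1`: 5340 nM

Compound 3 stands second highest of the three numbers. Its nearest neighbour is compound 1, and the step of a 1.5-fold higher number from compound 1 to compound 3 (0.17 log units; within the scatter) is within the scatter. Its furthest neighbour is compound 2, and the step of a 3.2-fold lower number from compound 2 to compound 3 (0.51 log units; beyond the scatter) is a modest one, beyond the scatter. The other measured step, a 4.8-fold higher number from compound 1 to compound 2 (0.68 log units; beyond the scatter), also sits beyond the scatter.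

Compound 4 is `N#Cc1c(Nc2ccccc2)nc(SCc2cn(Cc3ccccc3Cl)nn2)nc1-c1ccccc1`. It differs from compound 3 by hydrogen in place of fluoro on an aromatic carbon. In the wider reading the change is 4-fluorophenyl to phenyl, that is, (4-fluorophenyl)amino to anilino.

Going by the values given here, no measured step removes a substituent from this ring altogether; the two steps that touch this ring, a 1.5-fold higher number from compound 1 to compound 3 (0.17 log units; within the scatter) and a 3.2-fold lower number from compound 2 to compound 3 (0.51 log units; beyond the scatter), exchange one substituent for another. Of these, the exchange nearest in kind, chloro for fluoro at a different place, left the number within the scatter. On that basis the step of a 1.0-fold higher number from compound 3 to compound 4 (0.01 log units; within the scatter) is expected to stay within the scatter in this assay. Compound 4 is therefore estimated at 5500 nM, with a range from 2500 nM to 13000 nM.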

Compound 4, half-maximal inhibitory concentration: 28300 nM
Estimate against measurement, compound 4: 5.1-fold (0.71 log units) below, outside the stated range (above it).
By their numbers in this assay, from the lowest: compounds 1 and 3 (each within the scatter of the next); then compounds 2 and 4 (each within the scatter of the next).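

In this assay, the step of a 5.3-fold higher number from compound 3 to compound 4 (0.72 log units; beyond the scatter) shows that the fluoro group at this place is not a neutral passenger: taking it away, leaving the bare anilino group, weakens inhibition by a modest amount beyond the scatter. The step of a 7.9-fold higher number from compound 1 to compound 4 (0.90 log units; beyond the scatter) is also beyond the scatter, so both halogen-bearing compounds inhibit more strongly than the unsubstituted one, which the earlier exchanges of one substituent for another could not reveal. A substituent alone does not secure this gain, however, as the step of a 1.6-fold higher number from compound 2 to compound 4 (0.22 log units; within the scatter) stays within the scatter, so the nitro compound goes against any such pattern and cannot be told apart from the anilino compound, and nothing given here accounts for these differences.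

The compounds shown leave open whether the gain belongs to the halogens or to the place on the ring, since fluoro and chloro sit at different places and neither appears at the other's. They also leave open where a methoxy group, an amine or a carboxylic acid on this ring would fall, with the two halogen compounds or with the nitro and anilino pair.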